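A Fused Bicyclic Amine in Place of Isopropylpiperidine

This account rests on a few compounds, and the source may have more. Where it says the series, first, only, none or still open, it means among the compounds named here.

Among the three compounds measured so far, compound 3 `COc1ccc2[nH]c(C(=O)N3CC(=O)N(Cc4ccccc4)[C@@H](CN4CCC(C(C)C)CC4)C3)cc2c1` has the lowest number in a physicochemical assay for solubility, read by spectrophotometry, in phosphate buffer, with a stated time of 2 h, at pH 7.4 (a lower number here means a less soluble compound, a higher number a more soluble compound), at 12000 nM. Compound 2 `COc1ccc2[nH]c(C(=O)N3CC(=O)N(Cc4ccccc4)[C@@H](COc4ccc(F)cc4)C3)cc2c1` gives 17500 nM. Compound 1 `COc1ccc2[nH]c(C(=O)N3CC(=O)N(Cc4ccccc4)[C@@H](CN4CCC5(CC4)CC5)C3)cc2c1` gives 28200 nM. The step of a 1.5-fold lower number from compound 2 to compound 3 (0.16 log units; within the scatter) stays within the scatter, whereas the step of a 2.4-fold lower number from compound 1 to compound 3 (0.37 log units; beyond the scatter) is beyond it, so only compound 1 is clearly separated from compound 3.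

Compound 4 `COc1ccc2[nH]c(C(=O)N3CC(=O)N(Cc4ccccc4)[C@@H](CN4CC5CCCC5C4)C3)cc2c1` differs from compound 3 by a group of 8 heavy atoms (7 carbon, 1 nitrogen; one five-membered non-aromatic ring of carbon only, one five-membered non-aromatic ring with 1 hetero atom) in place of a group of 9 heavy atoms (8 carbon, 1 nitrogen; one six-membered non-aromatic ring with 1 hetero atom), on a saturated chain carbon bound to a saturated ring carbon. The step of a 2.4-fold lower number from compound 1 to compound 3 (0.37 log units; beyond the scatter) is the one that bears most on this change, as it went from a two-ring amine to a single-ring amine on the same chain carbon; the step of a 1.5-fold lower number from compound 2 to compound 3 (0.16 log units; within the scatter) is small and of little guidance. Compound 4 returns to a two-ring amine, so a modest upward step is expected, though the rings of compound 4 are fused rather than spiro, so a full return is uncertain. The expected step of a 1.7-fold higher number from compound 3 to compound 4 (0.22 log units; within the scatter) is modest and upward. Compound 4 is expected to give 20000 nM, within a range of 10000 nM to 40000 nM.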

Compound 4, solubility: 20700 nM
Beside the measured number, compound 4's estimate is 1.0-fold (0.01 log units) below it; low and high end bracket the measured number.
By their numbers in this assay, from the lowest: compounds 3, 2, 4 and 1 (each within the scatter of the next, the first and the last beyond it).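

In this assay, the two-ring amine of compound 4 cannot be told apart from any of the other three groups on this saturated chain carbon: the readings are a 1.7-fold higher number from compound 3 to compound 4 (0.24 log units; within the scatter) and a 1.2-fold higher number from compound 2 to compound 4 (0.07 log units; within the scatter) and a 1.4-fold lower number from compound 1 to compound 4 (0.13 log units; within the scatter), all within the scatter. Within the data shown here, compound 4 therefore sits within the scatter of both compound 1 and compound 3, the only pair beyond it, so the four compounds now form a continuous run rather than two separate levels. Two five-membered rings in compound 4 and the three-membered and six-membered rings in compound 1 give no separable reading, and no measurement shown offers a reason for any of these numbers.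

Going by these compounds, it remains open whether a morpholine or a piperazine on this chain carbon would stand apart from these four. On these data alone, a carboxylic acid there is equally open.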